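Oxan-4-yl in place of propyl on the aromatic carbon

The source may report more compounds than this note shows. Statements on the series, on what has been measured and on what is new or still open speak of the compounds shown alone.

Measured so far:
Compound 1, `CCCc1ccc(COC(=O)N[C@H]2CNC2=O)cc1`, gives 52 nM in an assay on HEK293 cells for inhibition of N-acylethanolamine-hydrolyzing acid amidase (Homo sapiens), read by fluorescence, with stated times of 10 min and 50 min; a higher number here means a weaker inhibitor, a lower number a stronger inhibitor.
Compound 2, `O=C(N[C@H]1CNC1=O)OCc1ccc2c(c1)CCC2`, gives 130 nM in this assay.

Compound 1 holds the lowest number of the two; compound 2 stands beyond the scatter above it. Compound 3, `O=C(N[C@H]1CNC1=O)OCc1ccc(C2CCOCC2)cc1`, differs from compound 1 by oxan-4-yl in place of propyl on an aromatic carbon. For the measured compounds named here, no pair of measured compounds isolates this change, so the step is judged from compound 1 alone. The step of a 1.5-fold higher number from compound 1 to compound 3 (0.19 log units; within the scatter) is expected to be small, toward a slightly higher number, not clearly beyond the scatter. Compound 3 is therefore estimated at 80 nM in this assay, with a likely range from 25 nM to 260 nM.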

Compound 3, half-maximal inhibitory concentration: 1370 nM
For compound 3 the middle estimate is 17-fold (1.23 log units) below the measured one, and the stated range ends below it.
By their numbers in this assay, from the lowest: compound 1; then compound 2; then compound 3.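

In this assay, oxan-4-yl in place of propyl on the aromatic carbon gives a 26-fold higher number from compound 1 to compound 3 (1.42 log units; beyond the scatter), the first step read in a single place in this series. This position, para to a large group, therefore responds strongly to the group it carries, and a ring with one oxygen does not stand in for the propyl chain. Nothing available accounts for the size of this step.

The compounds shown do not separate the contribution of the ring from that of its oxygen. Cyclohexyl and a longer chain such as butyl would bear on this question.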